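Methyl to Amino on the Shared Core: An Expected Step

The source may hold more compounds than are shown below. What is called first, only, known or untested is meant among the compounds shown, and "the series" means these compounds.

Measured so far:
compound 1, `C#CCOc1ccc(-c2cc(-c3ccccc3OCC#C)nc(-c3ccccc3)n2)cc1`: 14400 nM
compound 2, `C#CCOc1ccccc1-c1cc(-c2ccccc2OCC#C)nc(-c2ccccc2)n1`: 13800 nM
compound 3, `C#CCOc1ccc(-c2cc(-c3ccccc3OCC#C)nc(C)n2)cc1`: 18100 nM

All three were tested in an assay on BTI-TN-5B1-4 cells for inhibition of Amine oxidase [flavin-containing] B (Homo sapiens), read by fluorescence and Amplex Red, using microsomes, with a stated time of 30 min; a lower number here means a stronger inhibitor, a higher number a weaker inhibitor. Compound 3 has the highest of the three numbers, but its step from compound 1, a 1.3-fold higher number from compound 1 to compound 3 (0.10 log units; within the scatter), stays within the scatter, and its value and that of compound 2 sit close together as well. Compound 4, `C#CCOc1ccc(-c2cc(-c3ccccc3OCC#C)nc(N)n2)cc1`, has not yet been measured. The change is amino in place of methyl on an aromatic carbon. For the measured compounds named here, the only steps seen so far, a 1.0-fold lower number from compound 1 to compound 2 (0.02 log units; within the scatter) and a 1.3-fold higher number from compound 1 to compound 3 (0.10 log units; within the scatter), were both within the scatter, and neither involved an amino group, so no step beyond the scatter is expected for compound 4. Compound 4 is therefore estimated at 16000 nM, between 7000 nM and 36000 nM, an expected step of a 1.1-fold lower number from compound 3 to compound 4 (0.05 log units; within the scatter).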

Compound 4, half-maximal inhibitory concentration: 22100 nM
Beside the measured number, compound 4's estimate is 1.4-fold (0.14 log units) below it, within the range that was stated.
By their numbers in this assay, from the lowest: compounds 2, 1, 3 and 4 (each within the scatter of the next).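

In this assay, amino in place of methyl on the carbon between two ring nitrogen atoms gives a 1.2-fold higher number from compound 3 to compound 4 (0.09 log units; within the scatter), and amino in place of phenyl gives a 1.5-fold higher number from compound 1 to compound 4 (0.19 log units; within the scatter). Phenyl, methyl and amino at this place therefore all stay within the scatter of one another, even though only amino adds a hydrogen-bond donor. No measured evidence here bears on this result. From the compounds shown here alone, whether a carboxylic acid or a dimethylamino group at this place would move the number beyond the scatter remains open.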